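The compounds below may be only part of what the source reports. "The series", "measured", "known", "first", "only" and "open" are said of these compounds alone.

Three compounds of a shared core have been measured:

- compound 1, `NS(=O)(=O)c1ccc2c(c1)C(=O)C(=O)N2Cc1ccc(C(F)(F)F)cc1`, gives 8200 nM in a functional assay on MCF7 cells (Homo sapiens) for inhibition, read by MTT assay, with a stated time of 72 h; a lower number here means a stronger inhibitor, a higher number a weaker inhibitor
- compound 2, `NS(=O)(=O)c1ccc2c(c1)C(=O)C(=O)N2Cc1c(F)c(F)c(F)c(F)c1F`, gives 10200 nM in this assay
- compound 3, `NS(=O)(=O)c1ccc2c(c1)C(=O)C(=O)N2Cc1cccc(C(F)(F)F)c1`, gives 8400 nM in this assay

Compound 1 has the lowest of the three numbers, but this says little: its nearest neighbour, compound 3, sits within the scatter of it, and so does compound 2, the furthest of the three. All three values therefore look alike, and none of the compounds can be called the strongest or the weakest on these numbers alone.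

The fourth compound, compound 4, `NS(=O)(=O)c1ccc2c(c1)C(=O)C(=O)N2Cc1ccc(SC(F)(F)F)cc1`, has not yet been measured in this assay. It differs from compound 1 in one place: (trifluoromethyl)sulfanyl in place of trifluoromethyl on an aromatic carbon.

Among the measured compounds shown here, no pair of measured compounds differs in just one place, so there is no measured step to lean on. With the three known values all lying within the scatter of one another despite their different substituents, the step from compound 1 to compound 4 is expected to be small, in no clear direction, and not beyond the scatter: a 1.1-fold lower number from compound 1 to compound 4 (0.04 log units; within the scatter). Compound 4 is therefore estimated at 7500 nM, in a range from 3500 nM to 16000 nM.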

Compound 4, half-maximal inhibitory concentration: 2600 nM
Estimate against measurement, compound 4: 2.9-fold (0.46 log units) above, outside the stated range (below it).
By their numbers in this assay, from the lowest: compound 4; then compounds 1, 3 and 2 (each within the scatter of the next).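

In this assay, putting (trifluoromethyl)sulfanyl in place of trifluoromethyl on this aromatic carbon, para to a large group, gives a 3.2-fold lower number from compound 1 to compound 4 (0.50 log units; beyond the scatter), a modest step but the first difference in this set to lie beyond the scatter. The three earlier compounds carry different fluorinated rings, yet their values all lie within the scatter of one another, so they gave no sign that a change here could move the number; this exchange, which adds a single sulfur atom to the group, shows that it can. Why the number falls cannot be said, since no measurement that bears on a cause is available.

It remains open whether the sulfur-containing group is needed for this step, since the compounds shown do not include close relatives at this position such as trifluoromethoxy, with oxygen as the linking atom, or methylsulfanyl, which keeps the sulfur but has no fluorine. Also unanswered is whether the same exchange would give a similar step when made on compound 3, which carries its trifluoromethyl at a different place on the ring.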